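This account rests on a few compounds, and the source may have more. Where it says the series, first, only, none or still open, it means among the compounds named here.

Three compounds have been measured in a functional assay on HeLa cells (Homo sapiens) for antiproliferative activity, read by MTT assay, with a stated time of 72 h; on this read-out higher numbers stand for weaker inhibition and lower numbers for stronger inhibition:

Compound 1, `O=C1O[C@H]([C@@H](O)Cn2cc(-c3cccc(O)c3)nn2)C(OCc2ccccc2)=C1OCc1ccccc1`, gives 39300 nM.
Compound 2, `O=C1O[C@H]([C@@H](O)Cn2cc(-c3cc(F)cc(F)c3)nn2)C(OCc2ccccc2)=C1OCc1ccccc1`, gives 40800 nM.
Compound 3, `Cc1ccc(-c2cn(C[C@H](O)[C@H]3OC(=O)C(OCc4ccccc4)=C3OCc3ccccc3)nn2)cc1`, gives 25500 nM.

All three share the same core and differ only in the group attached to the aromatic carbon of the outer ring. Compound 3 has the smallest of the three numbers, yet a 1.5-fold lower number from compound 1 to compound 3 (0.19 log units; within the scatter) and a 1.6-fold lower number from compound 2 to compound 3 (0.20 log units; within the scatter), so the three compounds cannot be told apart on these data. The remaining measured step, a 1.0-fold higher number from compound 1 to compound 2 (0.02 log units; within the scatter), is also within the scatter: changing the group on that aromatic ring has so far made no visible difference.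

Compound 4, `CCCCCc1ccc(-c2cn(C[C@H](O)[C@H]3OC(=O)C(OCc4ccccc4)=C3OCc3ccccc3)nn2)cc1`, differs from compound 3 by butyl in place of hydrogen on a saturated chain carbon bound to an aromatic carbon. For the measured compounds named here, none of the measured steps involves lengthening a chain; they all swap one group for another on the aromatic ring, and each of them stayed within the scatter. There is therefore no measured basis for predicting a shift in either direction, and a step within the scatter is the expectation: a 1.3-fold lower number from compound 3 to compound 4 (0.11 log units; within the scatter) is expected. Compound 4 is accordingly estimated to give 20000 nM, with a range from 7000 nM to 55000 nM.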

Compound 4, half-maximal inhibitory concentration: 8390 nM
Beside the measured number, compound 4's estimate is 2.4-fold (0.38 log units) above it; the range from low to high includes it.
By their numbers in this assay, from the lowest: compound 4; then compounds 3, 1 and 2 (each within the scatter of the next).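

In this assay, for the compounds shown here, a change on the outer aromatic ring now gives a step beyond the scatter, which none of the earlier steps did: with butyl in place of hydrogen on the saturated chain carbon bound to an aromatic carbon, the methyl of the 4-methylphenyl group becomes a pentyl, and the result is a modest change (a 3.0-fold lower number from compound 3 to compound 4 (0.48 log units; beyond the scatter)). The 4-pentylphenyl group also stands apart from the 3,5-difluorophenyl group (a 4.9-fold lower number from compound 2 to compound 4 (0.69 log units; beyond the scatter)) and from the 3-hydroxyphenyl group (a 4.7-fold lower number from compound 1 to compound 4 (0.67 log units; beyond the scatter)), although the three groups it is compared with could not be told apart from one another, so this place does respond to at least one change. Nothing available explains why the pentyl compound gives the lowest number here.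

On these data alone, with only a methyl and a pentyl at this place, it remains open whether an ethyl or a propyl would already give part of the step, and whether a longer chain such as octyl would lower the number further or raise it again. As far as these compounds go, it is equally open whether a chain ending in an amine or a carboxylic acid would keep the step seen with the plain pentyl.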